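Halophenyl change on the shared core: working notes

The compounds below may be only part of what the source reports. "The series", "measured", "known", "first", "only" and "open" are said of these compounds alone.

Compound 1 `Cc1ccccc1-n1nncc1CN1C(=O)C2(C(C#N)=C(N)Oc3c2c2nc4ccccc4nc2c2ccccc32)c2ccccc21`: in a functional assay on MCF7 cells (Homo sapiens) for antiproliferative activity, read by MTT assay, with a stated time of 48 h (a higher number here means a weaker inhibitor, a lower number a stronger inhibitor), compound 1 reaches only the limit > 50000 nM, not a number.
Compound 2 `N#CC1=C(N)Oc2c(c3nc4ccccc4nc3c3ccccc23)C12C(=O)N(Cc1cnnn1-c1ccc(Br)cc1)c1ccccc12`: in this assay compound 2 gives 36600 nM.

Compound 2 holds the only number shown; the other value is a limit. Compound 3 `N#CC1=C(N)Oc2c(c3nc4ccccc4nc3c3ccccc23)C12C(=O)N(Cc1cnnn1-c1ccc(F)c(Cl)c1)c1ccccc12` differs from compound 2 in one place: 3-chloro-4-fluorophenyl in place of 4-bromophenyl on an aromatic nitrogen. Among the measured compounds shown here, the single measured step, an at least 1.3-fold lower number from compound 1 to compound 2 (0.13 log units; that floor lies within the scatter), starts from a limit of > 50000 nM in this assay, at which 1 of the 2 values shown sits, and its floor sits within the scatter, so it gives no direction for this change. For compound 3 no step beyond the scatter is expected: a 1.1-fold lower number from compound 2 to compound 3 (0.06 log units; within the scatter). Compound 3 is estimated at 32000 nM, between 12000 nM and 90000 nM.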

Compound 3, half-maximal inhibitory concentration: > 50000 nM
Compound 3: a limit, no number; the forecaster's own chance of this, stated with the estimate: 30%; middle value at least 1.5-fold (0.19 log units) away from the limit.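

With 3-chloro-4-fluorophenyl in place of 4-bromophenyl on the aromatic nitrogen, this assay gives an at least 1.3-fold higher number from compound 2 to compound 3 (0.13 log units; that floor lies within the scatter), so this change is not shown to move the number beyond the scatter. A second halophenyl group now sits at the limit, which shows that a halogen on this phenyl ring does not by itself give a number. Only compound 2 gives a number at this position, and the step from compound 1 to compound 3 cannot be read: the limit of > 50000 nM in this assay, at which 2 of the 3 values shown sit.

Going by these compounds, it remains open whether unsubstituted phenyl, 4-methoxyphenyl or a saturated cyclohexyl group on this nitrogen would give a number clearly under the limit.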